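A few compounds are considered here, and "the series" means these few. Any claim that something is new, unique, unknown or untested is made for them only; others in the source may bear on it.

Three compounds share one core, a cyclohexenone carrying a dienyl chain that ends in a substituted benzene ring. Compound 1 `O=C1C=CCC/C1=C\C=C\c1ccc(Cl)cc1` gives 4800 nM in a functional assay on HGC-27 cells (Homo sapiens) for cytotoxicity, read by MTT assay, with a stated time of 72 h (a higher number here means a weaker inhibitor, a lower number a stronger inhibitor), the highest of the three numbers, with compound 2 `O=C1C=CCC/C1=C\C=C\c1ccccc1[N+](=O)[O-]` at 4400 nM and compound 3 `COc1ccccc1/C=C/C=C1\CCC=CC1=O` at 3100 nM; all three lie within the scatter of one another. For the measured compounds named here, the one measured step, a 1.4-fold lower number from compound 2 to compound 3 (0.15 log units; within the scatter), shows that exchanging the ring substituent barely moves the number. Compound 4 `CN(C)c1ccc(/C=C/C=C2\CCC=CC2=O)cc1` differs from compound 1 by dimethylamino in place of chloro on an aromatic carbon. Going by the values given here, no measured step covers this exact change, but since the measured substituent exchanges stayed within the scatter, a step of about a 1.3-fold lower number from compound 1 to compound 4 (0.10 log units; within the scatter) is expected. Compound 4 is therefore estimated at 3800 nM, between 1500 nM and 9500 nM.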

Compound 4, half-maximal inhibitory concentration: 1500 nM
Compound 4: middle estimate off by 2.5-fold (0.40 log units), on the high side; the range from low to high includes it.
By their numbers in this assay, from the lowest: compound 4; then compounds 3, 2 and 1 (each within the scatter of the next).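

With dimethylamino in place of chloro on the aromatic carbon para to a large group, the change gives a 3.2-fold lower number from compound 1 to compound 4 (0.51 log units; beyond the scatter) in this assay. This modest change is the first step shown that lies beyond the scatter, so exchanging a ring substituent can move this number after all. Nothing available explains why this exchange does so. The compounds shown leave open whether a plain amino group or the longer diethylamino in this same place would give a similar step. A carboxylic acid there is also untested among these compounds.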